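From 4-Methylphenyl to 4-Bromobenzyl on a Ring Nitrogen

A few compounds are considered here, and "the series" means these few. Any claim that something is new, unique, unknown or untested is made for them only; others in the source may bear on it.

Three compounds share one core and differ only in the group on an amine nitrogen in a ring. Compound 1 `CCCn1c(=O)[nH]c2nc(-c3ccc(S(=O)(=O)N4CCN(c5cccc(Br)c5)CC4)cc3)[nH]c2c1=O` gives -1% in an assay on CHO cells for displacement of a labelled ligand from adenosine receptor A1 (Homo sapiens), read by scintillation counting, with a stated time of 90 min, tested at 1 uM, in the presence of a further agent that is not named here; a higher number here means more inhibition at the concentration tested (going by the name of the read-out), a lower number less inhibition. Compound 2 `CCCn1c(=O)[nH]c2nc(-c3ccc(S(=O)(=O)N4CCN(c5ccccc5F)CC4)cc3)[nH]c2c1=O` gives 13% and compound 3 `CCCn1c(=O)[nH]c2nc(-c3ccc(S(=O)(=O)N4CCN(c5ccc(C)cc5)CC4)cc3)[nH]c2c1=O` gives 12%. Compound 3 stands second highest of the three: its nearest neighbour is compound 2, within the scatter, and its furthest is compound 1, beyond the scatter. The measured steps are a number 14 percentage points higher from compound 1 to compound 2 (beyond the scatter), a number 13 percentage points higher from compound 1 to compound 3 (beyond the scatter) and a number 1 percentage points lower from compound 2 to compound 3 (within the scatter).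

Compound 4 `CCCn1c(=O)[nH]c2nc(-c3ccc(S(=O)(=O)N4CCN(Cc5ccc(Br)cc5)CC4)cc3)[nH]c2c1=O` differs from compound 3 by 4-bromobenzyl in place of 4-methylphenyl on an amine nitrogen in a ring. All three measured steps exchange one aromatic group for another on the same ring nitrogen, and the two steps beyond the scatter both move away from a bromine-bearing ring. For the measured compounds named here, no measured step inserts the extra carbon of a benzyl group, so those steps bear only loosely on this change. The step of a number 5 percentage points lower from compound 3 to compound 4 (within the scatter) is therefore expected to be small, leaning slightly downward, and probably within the scatter. Compound 4 is expected to give 7%, between -8% and 22%.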

Compound 4, a percentage reported as inhibition, at one concentration (the size of the read-out at that concentration, not a potency): 31%
Compound 4: middle estimate off by 24 percentage points, on the low side; the measured number lies above the stated range.
By their numbers in this assay, from the lowest: compound 1; then compounds 3 and 2 (each within the scatter of the next); then compound 4.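

Compound 4 shows that this position can carry a group that lifts the number in this assay beyond the scatter of all three earlier compounds (a number 19 percentage points higher from compound 3 to compound 4 (beyond the scatter); a number 18 percentage points higher from compound 2 to compound 4 (beyond the scatter); a number 32 percentage points higher from compound 1 to compound 4 (beyond the scatter)). Bromine alone does not sort these numbers: compound 1 and compound 4 both carry it yet sit at opposite ends of the series, and the benzyl group's extra carbon is the other feature that sets compound 4 apart. Nothing shown here explains the rise.

Still open, from the compounds shown here alone, is whether the extra carbon, the bromine or the two together account for the higher number, and a plain benzyl or a 4-bromophenyl group on the same nitrogen would help separate them. Also open, going by these compounds, is how a longer chain, such as 2-phenylethyl, would fare at this position.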